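The source may report more compounds than this note shows. Statements on the series, on what has been measured and on what is new or still open speak of the compounds shown alone.

Measured compounds in a physicochemical assay for solubility, read by LC-MS, in phosphate buffer, with a stated time of 24 h, at pH 7.4; on this read-out lower numbers stand for lower solubility and higher numbers for higher solubility: compound 1 `Cn1cc(-c2cnc(NCc3c(F)ccc4c3CCO4)c3cn[nH]c(=O)c23)cn1` gives 1000 nM; compound 2 `CN(c1cccnc1)c1cnc(NCc2c(F)ccc3c2CCO3)n2cnnc12` gives 47000 nM; compound 3 `CN(c1ccn(C)n1)c1cnc(NCc2c(F)ccc3c2CCO3)n2cnnc12` gives 130000 nM.

Compound 1 stands lowest of the three, well apart from both others. Among the compounds with values here, the only measured step, a 2.8-fold higher number from compound 2 to compound 3 (0.44 log units; beyond the scatter), concerns a different core and a change on a nitrogen, so it does not bear directly on the step to compound 4 `Cc1ncc(-c2cnc(NCc3c(F)ccc4c3CCO4)c3cn[nH]c(=O)c23)n1C`, which carries 1,2-dimethyl-1H-imidazol-5-yl in place of 1-methyl-1H-pyrazol-4-yl on an aromatic carbon. Within the data shown here, with no comparable step among the measured compounds, the change in this assay is expected to be small, at most a modest rise. Compound 4 is therefore estimated at 2500 nM, within 800 nM to 8000 nM, an expected step of a 2.5-fold higher number from compound 1 to compound 4 (0.40 log units; beyond the scatter).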

Compound 4, solubility: 15000 nM
Estimate against measurement, compound 4: 6.0-fold (0.78 log units) below; the measured number lies above the stated range.
By their numbers in this assay, from the lowest: compound 1; then compound 4; then compound 2; then compound 3.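

Within the data shown here, at this position on the core of compound 1, the ring on the aromatic carbon matters far more than the earlier compounds could show: in this assay the swap to 1,2-dimethyl-1H-imidazol-5-yl gives a 15-fold higher number from compound 1 to compound 4 (1.18 log units; beyond the scatter) as a large step. The two rings match in hydrogen-bond donors, acceptors and charge, and the entering group has one more carbon. Nothing measured here explains the size of this step. 

Going by these compounds, it remains open whether the extra methyl or the changed ring drives the step, which 1-methyl-1H-imidazol-5-yl could separate. On these data alone, how a ring carrying an amine would behave here also remains open.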